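Methoxy addition on the phenol ring of compound 1

This account rests on a few compounds, and the source may have more. Where it says the series, first, only, none or still open, it means among the compounds named here.

Compound 1 `COc1ccc(C(=O)/C=C/c2ccc(O)c(CN3CCN(c4ccnc5cc(Cl)ccc45)CC3)c2)c(OC)c1` is the longer-lived of the two compounds measured in an in vitro ADME assay on microsomes from liver (Mus musculus) for metabolic stability, read by LC-MS, using NADPH, tested at 1 uM, in the presence of a further agent that is not named here; a lower number here means that the compound disappears faster, a higher number that the compound lasts longer. In this assay compound 1 gives 0.757 h. The only comparator, compound 2 `COc1cc(/C=C/C(C)=O)ccc1OCCNc1ccnc2cc(Cl)ccc12`, gives 0.223 h; the gap between the two values is beyond the usual scatter, but the two structures differ in many places at once, so no single change can be read from that pair. Within the data shown here, no step between compounds differing in one place is available in this assay.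

Compound 3 `COc1ccc(C(=O)/C=C/c2cc(CN3CCN(c4ccnc5cc(Cl)ccc45)CC3)c(O)c(OC)c2)c(OC)c1` keeps the whole core of compound 1 and differs from it in one place: methoxy in place of hydrogen on an aromatic carbon. Among the measured compounds shown here, there is no measured precedent for such a change, so the direction cannot be anchored on data. A modest step is expected, most likely within the scatter or slightly toward faster disappearance, and the estimated step from compound 1 to compound 3 is a 1.3-fold lower number from compound 1 to compound 3 (0.10 log units; within the scatter). Compound 3 is expected to give about 0.6 h in this assay, with a plausible range from 0.3 h to 1.2 h.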

Compound 3, half-life in the liver assay: 0.197 h
Beside the measured number, compound 3's estimate is 3.0-fold (0.48 log units) above it; measured number outside the range, below it.
By their numbers in the liver assay, from the lowest: compounds 3 and 2 (each within the scatter of the next); then compound 1.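

Among these compounds, in the liver assay, methoxy in place of hydrogen on an aromatic carbon, ortho to a hydroxy group, gives a 3.8-fold lower number from compound 1 to compound 3 (0.58 log units; beyond the scatter) as the first step that can be read at a single place, so this position on the core of compound 1 is not indifferent to substitution in this assay. In a physicochemical assay for lipophilicity, read by HPLC, at pH 7.4 (a lower number here means a more polar compound, a higher number a more lipophilic compound), compound 1 gives 5.3 and compound 3 gives 5 and the printed step, a number 0.30 log units lower from compound 1 to compound 3 (within the scatter), does not separate the two compounds. No measurement at hand bears on the cause of the step in stability, which therefore stands as an observation only.

As far as these compounds go, it remains open whether the step belongs to methoxy itself or to any substituent on this aromatic carbon, a question that a fluorine atom or a longer chain such as ethoxy at the same place would address. From the compounds shown here alone, it also remains open whether the step depends on the neighbouring hydroxy group, which a compound carrying a methyl ether in place of that hydroxy group, with the new methoxy kept, would test.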